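The source may report more compounds than this note shows. Statements on the series, on what has been measured and on what is new or still open speak of the compounds shown alone.

Of the compounds shown here, three from one series have been measured in an assay on isolated protein for inhibition of aldehyde dehydrogenase 1A1 (Homo sapiens), read by spectrophotometry, tested at 10 uM; a lower number here means less inhibition, a higher number more inhibition at the concentration tested (going by the name of the read-out). Compound 1 `Cc1cccc(Cn2c(CN3CCN(C(=O)c4ccc(Cl)cc4)CC3)nc3ccccc32)c1` gives 23.2% in this assay. Compound 2 `Cc1cccc(Cn2c(CN3CCN(C(=O)c4ccc(F)cc4)CC3)nc3ccccc32)c1` differs from compound 1 only in that (fluoro in place of chloro on an aromatic carbon). In this assay compound 2 gives 27.1%; the step is a number 3.9 percentage points higher from compound 1 to compound 2 (within the scatter). Compound 3 `O=C(C1CC1)N1CCN(Cc2nc3ccccc3n2Cc2cccc(Cl)c2)CC1` gives 71.6% in this assay, the highest of the three numbers, and its distance to each of compound 1 and compound 2 lies beyond the scatter. How the core of compound 3 differs from the core of compound 1 is not broken down here.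

Compound 4 `O=C(C1CC1)N1CCN(Cc2nc3ccccc3n2Cc2cccc(F)c2)CC1` has not yet been measured. It differs from compound 3 only in that (fluoro in place of chloro on an aromatic carbon). Among the compounds with values here, this is the same kind of change as the one from compound 1 to compound 2, but not the same: in compound 1 and compound 2 the place is para to a large group, whereas in compound 3 and compound 4 it is meta to a large group, and the surrounding ring belongs to the benzyl group rather than to the carbonyl-bearing ring.

Within the data shown here, the one measured instance of this change, from compound 1 to compound 2, stayed within the scatter, so the step from compound 3 to compound 4 is expected to be small as well, a number 0.4 percentage points higher from compound 3 to compound 4 (within the scatter), resting on a number 3.9 percentage points higher from compound 1 to compound 2 (within the scatter). Compound 4 is therefore estimated to give about 72% in this assay, most likely between 58% and 84%.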

Compound 4, a percentage reported as inhibition, at one concentration (the size of the read-out at that concentration, not a potency): 27.2%
For compound 4 the middle estimate is 44.8 percentage points above the measured one, outside the stated range (below it).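

In this assay, the exchange of chloro for fluoro on the 3-chlorobenzyl group of compound 3 is far from neutral, giving a number 44.4 percentage points lower from compound 3 to compound 4 (beyond the scatter). The same exchange therefore did not carry over from one core to the other in this series, and the two measured instances disagree: the same change on two cores in this assay, a number 3.9 percentage points higher (within the scatter) from compound 1 to compound 2 and a number 44.4 percentage points lower (beyond the scatter) from compound 3 to compound 4, 48.3 percentage points apart, beyond the scatter of two such steps This does not show which difference between the two cases separates the steps, since the halogen sits on a different ring in each pair and the rest of the molecule also differs, and two instances give no rule for any further core in the series.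

The compounds shown leave open whether compound 3 owes its higher number to chloro in particular, or whether a bromo, a methoxy or a trifluoromethyl group in the same place would hold that number or fall to the level of compound 4. They also leave open how the exchange of chloro for fluoro would behave on the benzyl ring when the cyclopropyl carbonyl is replaced by a benzoyl group, which would separate the effect of the ring carrying the halogen from that of the rest of the core.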